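The compounds below may be only part of what the source reports. "The series", "measured", "known", "first", "only" and "open" are said of these compounds alone.

Four compounds share one core, each carrying a sugar and a small five-membered aromatic ring. Compound 1 `COc1ncnc2c1c(-c1ccsc1)cn2[C@@H]1O[C@H](CO)[C@@H](O)[C@H]1O` bears a thiophen-3-yl group and a methoxy group. In a functional assay on CCRF-CEM cells (Homo sapiens), read by MTT assay, with a stated time of 72 h (on this read-out higher numbers stand for weaker inhibition and lower numbers for stronger inhibition), compound 1 gives 2570 nM. Compound 2 `COc1ncnc2c1c(-c1ccoc1)cn2[C@@H]1O[C@H](CO)[C@@H](O)[C@H]1O` differs from compound 1 by a single change, (furan-3-yl in place of thiophen-3-yl on an aromatic carbon), and in this assay compound 2 gives 110 nM. That swap made a 23-fold lower number from compound 1 to compound 2 (1.37 log units; beyond the scatter). Compound 3 `CNc1ncnc2c1c(-c1ccsc1)cn2[C@@H]1O[C@H](CO)[C@@H](O)[C@H]1O` keeps the thiophen-3-yl group, and its core differs from the core of compound 1 by methylamino in place of methoxy on an aromatic carbon. In this assay compound 3 reaches only a limit of the assay, > 20000 nM, so no number is known for it. The step made was an at least 7.7-fold higher number from compound 1 to compound 3 (0.89 log units; beyond the scatter), with compound 3 sitting at the limit of > 20000 nM in this assay, at which 1 of the 3 values shown sits.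

Compound 4 `CNc1ncnc2c1c(-c1ccoc1)cn2[C@@H]1O[C@H](CO)[C@@H](O)[C@H]1O` has not yet been measured. It differs from compound 3 by furan-3-yl in place of thiophen-3-yl on an aromatic carbon. The place of this change is the same, word for word, as in the step from compound 1 to compound 2, so it is the same change, seen twice among these compounds. On these data alone, the step from compound 3 to compound 4 in this assay is expected to be an at least 5.0-fold lower number from compound 3 to compound 4 (0.69 log units; beyond the scatter), set beside a 23-fold lower number from compound 1 to compound 2 (1.37 log units; beyond the scatter), an expectation resting on that one earlier pair and weakened by compound 3 giving only a limit, > 20000 nM, so the starting point is unknown. Compound 4 is expected to give about 4000 nM in this assay, estimated to lie between 900 nM and 20000 nM.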

Compound 4, half-maximal inhibitory concentration: > 20000 nM
Compound 4: only a limit was reported; the forecaster's own chance of this, stated with the estimate: 30%; middle value at least 5.0-fold (0.69 log units) from the limit.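

In this assay compound 3 and compound 4 both sit at a limit of the assay, so the swap of thiophen-3-yl for furan-3-yl cannot be read on the methylamino core, and nothing shows whether the gain seen on the methoxy core, a 23-fold lower number from compound 1 to compound 2 (1.37 log units; beyond the scatter), carries over or is lost: the limit of > 20000 nM in this assay, at which 2 of the 4 values shown sit.

Among these compounds, the one new step that can be read belongs to the other change, methylamino in place of methoxy, which gives an at least 180-fold higher number from compound 2 to compound 4 (2.25 log units; beyond the scatter). That change now points the same way on both the thiophen-3-yl and the furan-3-yl compounds, so a higher number with methylamino is seen twice among these four compounds, but its true size on each remains unknown: the same change on two cores in this assay, an at least 7.7-fold higher number (0.89 log units; beyond the scatter) from compound 1 to compound 3 and an at least 180-fold higher number (2.25 log units; beyond the scatter) from compound 2 to compound 4; the limit leaves it open whether they differ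

The compounds shown leave open whether a furan-3-yl gain could be seen at all with a nitrogen group at this place, which would take a member that lands clear of the limit, perhaps one carrying a plain amino group or an ethoxy group in place of the methylamino group. They also leave open how other five-membered rings, such as furan-2-yl or thiophen-2-yl, would compare on either core.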